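Methylsulfanyl for chloro on the oxazole of compound 3

The source may report more compounds than this note shows. Statements on the series, on what has been measured and on what is new or still open speak of the compounds shown alone.

Measured so far in an assay on HEK-293T cells for inhibition of diacylglycerol lipase-alpha (Homo sapiens), read by colorimetric assay; a higher number here means a weaker inhibitor, a lower number a stronger inhibitor:
- compound 1 `O=C(CCCCCCc1ccccc1)c1nnn[nH]1`: reported only as a limit of the assay, > 10000 nM; > 10000 nM (2 entries)
- compound 2 `CC(=O)c1coc(C(=O)CCCCCCc2ccccc2)n1`: 123 nM
- compound 3 `O=C(CCCCCCc1ccccc1)c1nc(Cl)co1`: 2400 nM

Compound 3 carries the highest of the two numbers obtained in this assay; compound 2 gives the lower one. Compound 1 stands apart as a limit. Within the data shown here, the only measured step is a 20-fold higher number from compound 2 to compound 3 (1.29 log units; beyond the scatter), an exchange of acetyl for chloro on an aromatic carbon. Compound 4 `CSc1coc(C(=O)CCCCCCc2ccccc2)n1` differs from compound 3 by methylsulfanyl in place of chloro on an aromatic carbon. Among the measured compounds shown here, no measured step exchanges chloro for methylsulfanyl, so the acetyl-to-chloro step shows only that this position can move the number a long way, without fixing a direction for compound 4. For compound 4 the step of a 1.6-fold lower number from compound 3 to compound 4 (0.20 log units; within the scatter) is expected, within the scatter. Compound 4 is therefore estimated at 1500 nM, with a range from 400 nM to 6000 nM.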

Compound 4, half-maximal inhibitory concentration: > 10000 nM
Compound 4 gave a limit, no number; the forecaster's own chance of this, stated with the estimate: 10%; middle value at least 6.6-fold (0.82 log units) from the limit.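

In this assay compound 4 gives > 10000 nM, a limit of the assay and not a number. Among these compounds, the direction left unfixed by the earlier compounds is now settled, with methylsulfanyl for chloro giving an at least 4.1-fold higher number from compound 3 to compound 4 (0.61 log units; beyond the scatter) and methylsulfanyl for acetyl giving an at least 81-fold higher number from compound 2 to compound 4 (1.91 log units; beyond the scatter). Of the three groups on this aromatic carbon, acetyl carries the lowest number, with its steps to both others beyond the scatter.

As far as these compounds go, how far compound 4 lies past the limit stays open. So does whether a methyl ester or an amide on this carbon would match acetyl.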